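Ethoxy to Acetoxy: A Small Exchange on the Strongest Inhibitor

The source may hold more compounds than are shown below. What is called first, only, known or untested is meant among the compounds shown, and "the series" means these compounds.

Of the compounds shown here, three have so far been measured in a functional assay on RAW264.7 cells (Mus musculus) for inhibition, read by Griess assay, with a stated time of 24 h; a higher number here means a weaker inhibitor, a lower number a stronger inhibitor. Compound 1 `COc1cc(O)c(C(=O)/C=C/c2ccc(OCCCN3CCCC3)c(OC)c2)c(OC)c1` gives 6500 nM, and compound 2 `COc1cc(O)c(C(=O)/C=C/c2ccc(C)cc2)c(OC)c1` gives 6300 nM, two values within the usual scatter of each other. Compound 3 `CCOc1cc(OC)cc(OC)c1C(=O)/C=C/c1cccc(OC)c1` gives 2700 nM, the lowest number of the three, which makes it the strongest inhibitor among them. Its distance from each of the other two lies beyond the scatter, though not by much. Among the compounds with values here, these three compounds differ in more than one place, so no measured step isolates a single change.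

Compound 4 `COc1cccc(/C=C/C(=O)c2c(OC)cc(OC)cc2OC(C)=O)c1` has not yet been measured in this assay. It departs from compound 3 in one place, with acetyl in place of ethyl on an oxygen on an aromatic ring, or ethoxy to acetoxy: acetyl in place of ethyl on an oxygen on an aromatic ring. Within the data shown here, the data hold no example of this exchange, so the expectation starts from compound 3 at 2700 nM and allows a wide margin. No change beyond the scatter is expected, with only a slight lean towards a weaker inhibitor. The expected change is a 1.2-fold higher number from compound 3 to compound 4 (0.07 log units; within the scatter). For compound 4 the estimated value is 3200 nM, with an expected range from 1200 nM to 8000 nM.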

Compound 4, half-maximal inhibitory concentration: 3600 nM
Compound 4: middle estimate off by 1.1-fold (0.05 log units), on the low side; the range from low to high includes it.
By their numbers in this assay, from the lowest: compounds 3, 4, 2 and 1 (each within the scatter of the next, the first and the last beyond it).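

In this assay, within the data shown here, the step reads a 1.3-fold higher number from compound 3 to compound 4 (0.12 log units; within the scatter), which is the first measured exchange at this oxygen on an aromatic ring, and it shows that ethyl and acetyl cannot be told apart here. Acetyl brings one hydrogen-bond acceptor and one double bond outside aromatic rings, neither of which ethyl has, and with these additions the numbers of the two compounds still lie within the usual scatter, so this position tolerates at least this one exchange without a measurable shift. No available evidence bears on why the exchange has so little effect on the read-out, and nothing here speaks to what the acetyl group does in the cells.

The compounds shown place only ethyl and acetyl on this oxygen in otherwise identical molecules, so it remains open how a longer chain such as butyl, a carboxylic acid-bearing chain or an amine-bearing chain would read in this assay at the same place. On these data alone, it is also open whether the exchange of ethyl for acetyl would read the same way on the differently substituted compounds 1 and 2.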